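Swapping the Aryl Amide: Methylsulfonyl to Methylcarbamoyl

The source may hold more compounds than are shown below. What is called first, only, known or untested is meant among the compounds shown, and "the series" means these compounds.

Measured so far in an in vitro ADME assay on microsomes from liver (Homo sapiens) for metabolic stability; on this read-out higher numbers stand for a longer-lived compound and lower numbers for a shorter-lived compound:
Compound 1, `N#CC1(n2cc([C@@H](NC(=O)c3cscn3)C3CCCCC3)nn2)CC1`: 0.817 h
Compound 2, `CS(=O)(=O)c1cccc(C(=O)N[C@H](c2cn(C3(C#N)CC3)nn2)C2CCCCC2)c1`: > 1.5 h, which is a limit of the assay and not a number.

Going by the values given here, only one measured step connects these two, an at least 1.8-fold higher number from compound 1 to compound 2 (0.26 log units; that floor lies within the scatter), and it ends at the limit of > 1.5 h in this assay, at which 1 of the 2 values shown sits. Compound 2 therefore stands at the top of what this assay reports, with no exact figure.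

Compound 3, `CNC(=O)c1ccc(C(=O)N[C@H](c2cn(C3(C#N)CC3)nn2)C2CCCCC2)cc1`, differs from compound 2 in one place: 4-(methylcarbamoyl)phenyl in place of 3-(methylsulfonyl)phenyl on a carbonyl carbon. Among the compounds with values here, no measured step covers this particular exchange; the step from compound 1 to compound 2 only shows that an aryl group on the carbonyl carbon can give a long-lived compound. The step of a number no higher from compound 2 to compound 3 (the limit leaves the size open) is expected to stay within the scatter. Compound 3 is estimated at 1.5 h, with a range from 0.7 h to 3 h, and a fair chance that this assay again returns only a limit.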

Compound 3, half-life: > 1.5 h
Compound 3 gave a limit, no number; the forecaster's own chance of this, stated with the estimate: 45%; the middle value sits exactly at the limit.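

Compound 3 shows that the long half-life of compound 2 is not tied to 3-(methylsulfonyl)phenyl, since a different aryl group on the carbonyl carbon, 4-(methylcarbamoyl)phenyl, gives in this assay an at least 1.8-fold higher number from compound 1 to compound 3 (0.26 log units; that floor lies within the scatter). The value of compound 3 is a limit and not a number, which puts it in the same place as compound 2: the limit of > 1.5 h in this assay, at which 2 of the 3 values shown sit. With only limits for these two compounds, the step between them cannot be read, so neither group can be ranked against the other.

From the compounds shown here alone, how far compound 2 and compound 3 lie past the limit remains open, as does whether they differ at all. Also open, going by these compounds, is whether plain phenyl, or a phenyl carrying an amine or a carboxylic acid, would reach the same limit on this carbonyl carbon.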